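The compounds below may be only part of what the source reports. "The series", "measured", "known", "first", "only" and "open" are said of these compounds alone.

Compound 1 `Cc1ccc2nc(-c3ccc(N)cc3)cn2c1` gives 82900 nM in a functional assay on HT-29 cells (Homo sapiens) for antiproliferative activity, read by MTT assay, with a stated time of 72 h; on this read-out higher numbers stand for weaker inhibition of growth and lower numbers for stronger inhibition of growth. Compound 2 `Cc1ccc2nc(-c3ccc(NCc4ccccc4)cc3)cn2c1` carries one change, (benzyl in place of hydrogen on a nitrogen on an aromatic ring), and in this assay compound 2 gives 8800 nM, so that a 9.4-fold lower number from compound 1 to compound 2 (0.97 log units; beyond the scatter). Compound 3 `Cc1ccn2cc(-c3ccc(NCc4ccccc4)cc3)nc2c1` is built on a different core; the difference between the two cores is not broken down here. In this assay compound 3 gives 17500 nM. Compound 4 `Cc1ccn2cc(-c3ccc(N(Cc4ccccc4)Cc4ccccc4)cc3)nc2c1` has not been measured yet; it differs from compound 3 by benzyl in place of hydrogen on a nitrogen on an aromatic ring. This is the same kind of change as that from compound 1 to compound 2, not the same one: in compound 1 the nitrogen had only an aromatic carbon as other neighbour, while in compound 3 it already has an aromatic carbon and a saturated chain carbon. A smaller step is expected here, a 1.9-fold lower number from compound 3 to compound 4 (0.29 log units; within the scatter), because a 9.4-fold lower number from compound 1 to compound 2 (0.97 log units; beyond the scatter) came on a nitrogen that then bore only an aromatic carbon, and the second benzyl lands on a nitrogen already carrying one. Compound 4 is thus estimated at 9000 nM, with a likely range from 3000 nM to 30000 nM.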

Compound 4, concentration for 50% growth inhibition: 6900 nM
Compound 4: middle estimate off by 1.3-fold (0.12 log units), on the high side, and the stated range covers the measured number.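

On the core of compound 3, a second benzyl on the nitrogen gives a 2.5-fold lower number from compound 3 to compound 4 (0.40 log units; beyond the scatter) in this assay, so the change again goes towards stronger inhibition of growth. The direction carries from one core to the other, but the size does not: the same change on two cores in this assay, a 9.4-fold lower number (0.97 log units; beyond the scatter) from compound 1 to compound 2 and a 2.5-fold lower number (0.40 log units; beyond the scatter) from compound 3 to compound 4, 3.7-fold (0.57 log units) apart, beyond the scatter of two such steps

The two steps differ both in the core and in what the nitrogen already carried, so these compounds cannot show which of the two sets the size of the step. Also open, as far as these compounds go, is how a second benzyl would act on the core of compound 2. From the compounds shown here alone, whether a smaller group on the nitrogen, such as methyl or acetyl, would follow the same direction on both cores also remains open.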